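Notes on the shared core, methyl to cyano

A few compounds are considered here, and "the series" means these few. Any claim that something is new, unique, unknown or untested is made for them only; others in the source may bear on it.

Compound 3 `Cc1cnc(-c2nn(Cc3ccccc3F)c3ncccc23)nc1N` gives 675000 nM in a functional assay (aorta) with Oryctolagus cuniculus as the target (on this read-out higher numbers stand for weaker inhibition and lower numbers for stronger inhibition), the highest number among the three measured; compound 1 `OCc1ccnc(-c2nn(Cc3ccccc3F)c3ncccc23)n1` gives 1300 nM and compound 2 `Fc1ccccc1Cn1nc(-c2nn[nH]n2)c2cccnc21` gives 8600 nM. The measured steps, a 520-fold higher number from compound 1 to compound 3 (2.72 log units; beyond the scatter) and a 78-fold higher number from compound 2 to compound 3 (1.89 log units; beyond the scatter), together with a 6.6-fold higher number from compound 1 to compound 2 (0.82 log units; beyond the scatter), each swap the whole aromatic substituent, so none bears directly on the change to compound 4 `N#Cc1cnc(-c2nn(Cc3ccccc3F)c3ncccc23)nc1N`: cyano in place of methyl on an aromatic carbon. Among the measured compounds shown here, no measured step tests cyano against methyl, and no direction beyond the scatter is therefore expected, though the uncertainty is wide. The expected step is a 2.3-fold lower number from compound 3 to compound 4 (0.35 log units; beyond the scatter), giving compound 4 an estimate of 300000 nM with a range from 40000 nM to 2000000 nM.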

Compound 4, half-maximal inhibitory concentration: 391000 nM
The estimate for compound 4 lay 1.3-fold (0.12 log units) below the measured number, within the range that was stated.
By their numbers in this assay, from the lowest: compound 1; then compound 2; then compounds 4 and 3 (each within the scatter of the next).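

Cyano in place of methyl on an aromatic carbon ortho to an amino group gives a 1.7-fold lower number from compound 3 to compound 4 (0.24 log units; within the scatter) in this assay and so does not separate the two compounds on this read-out. Unlike the earlier steps, which swap the whole aromatic substituent, this one changes a single small group, and the added hydrogen-bond acceptor of cyano brings no step beyond the scatter. Nothing at hand bears on why. From the compounds shown here alone, whether chlorine, a carboxylic acid or a longer chain at this carbon would shift the number beyond the scatter stays open. So does the contribution of the amino group itself.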